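The source may report more compounds than this note shows. Statements on the series, on what has been measured and on what is new or still open speak of the compounds shown alone.

Compound 1 `COc1ccc(S(=O)(=O)/C=C/c2ccccn2)cc1` is the starting point. In an ADME assay on BV-2 cells (Mus musculus) for cytotoxicity, with a stated time of 24 h, tested at 50 uM (on this read-out lower numbers stand for a stronger effect and higher numbers for a weaker effect at the one concentration tested), compound 1 gives 100%, the highest of the two numbers measured; the nearest is compound 2 `COc1ccc(S(=O)(=O)/C=C/c2ncccc2Cl)cc1`, which in this assay gives 89.8%, a step of a number 10.2 percentage points lower from compound 1 to compound 2 (beyond the scatter). Compound 3 `COc1ccc(S(=O)(=O)/C=C/c2cccnc2)cc1` differs from compound 1 by pyridin-3-yl in place of pyridin-2-yl on a double-bonded chain carbon bound to a double-bonded chain carbon. Within the data shown here, the one measured step concerns a different change, so no step bears directly on this one, and the chloro step was only modest. A change of no more than the scatter is therefore expected for compound 3, with this assay estimated at 96%, between 82% and 105%, a step of a number 4 percentage points lower from compound 1 to compound 3 (within the scatter) from compound 1.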

Compound 3, a percentage reported as activity, at one concentration (the size of the read-out at that concentration, not a potency): 85.8%
Compound 3: middle estimate off by 10.2 percentage points, on the high side; measured number inside the range.
By their numbers in this assay, from the lowest: compounds 3 and 2 (each within the scatter of the next); then compound 1.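

Swapping pyridin-2-yl for pyridin-3-yl on a double-bonded chain carbon keeps the same atoms, yet in this assay it gives a step of its own, a number 14.2 percentage points lower from compound 1 to compound 3 (beyond the scatter). The read-out at this place therefore responds to how the pyridine ring is joined, not only to an added group such as chloro. No available evidence accounts for this difference. Still open, as far as these compounds go, is how pyridin-4-yl or a plain phenyl ring would behave at this place. Also open, from the compounds shown here alone, is whether chloro on the pyridin-3-yl ring would give any further step.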